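The source may report more compounds than this note shows. Statements on the series, on what has been measured and on what is new or still open speak of the compounds shown alone.

Measured so far:

- compound 1, `COc1ccc(C2=C(c3cc(OC)c(OC)c(OC)c3)C(=O)C(OC(C)=O)C2)cc1F`: 16 ug/mL
- compound 2, `COc1ccc(C2=C(c3cc(OC)c(OC)c(OC)c3)CC(O[SiH2]C(C)(C)C)C2=O)cc1[N+](=O)[O-]`: a limit only, > 100 ug/mL
- compound 3, `COC(=O)c1cc(C2=C(c3cc(OC)c(OC)c(OC)c3)C(=O)CC2O[SiH2]C(C)(C)C)ccc1OC`: a limit only, > 100 ug/mL

In an ADME assay on DU-145 cells (Homo sapiens) for cytotoxicity, read by MTT assay, with a stated time of 72 h (on this read-out higher numbers stand for weaker inhibition and lower numbers for stronger inhibition), compound 1 gives 16 ug/mL. For compound 2 the read-out is a limit of the assay rather than a number, > 100 ug/mL. For compound 3 the same holds: it gives only > 100 ug/mL, a limit of the assay. So compound 3 stands at the limit of > 100 ug/mL in this assay, at which 2 of the 3 values shown sit, and no number is known for it. Compound 4, `COc1ccc(OC)c(C2=C(c3cc(OC)c(OC)c(OC)c3)C(=O)CC2O[SiH2]C(C)(C)C)c1`, has not yet been measured. It differs from compound 3 in one place: 2,5-dimethoxyphenyl in place of 4-methoxy-3-(methoxycarbonyl)phenyl on a double-bonded ring carbon. Going by the values given here, no pair of measured compounds differs in just one place, so there is no measured step to lean on. Compound 4 is expected to stay close to where compound 3 sits, so the step of an at least 1.2-fold lower number from compound 3 to compound 4 (0.09 log units; that floor lies within the scatter) is estimated as none beyond the usual scatter, with a fair chance that only a limit is reported again due to the limit of > 100 ug/mL in this assay, at which 2 of the 3 values shown sit. For compound 4 the estimate is 80 ug/mL, within a range from 20 ug/mL to 300 ug/mL.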

Compound 4, half-maximal inhibitory concentration: 100 ug/mL
Estimate against measurement, compound 4: 1.3-fold (0.10 log units) below; the range from low to high includes it.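

In this assay, putting 2,5-dimethoxyphenyl in place of 4-methoxy-3-(methoxycarbonyl)phenyl on a double-bonded ring carbon gives a number no higher from compound 3 to compound 4 (the limit leaves the size open). Compound 3 has only a limit of the assay, > 100 ug/mL. Compound 4 does give a number, 100 ug/mL, so this ring carbon can hold an aryl group that returns a reading. How much the swap changes the reading cannot be told because one side of the comparison is a limit: the limit of > 100 ug/mL in this assay, at which 2 of the 4 values shown sit.

As far as these compounds go, how a phenyl ring carrying an amine or a carboxylic acid would read at this ring carbon stays open. Compound 1 differs from compound 4 in more than one place, so the compounds shown do not tell which change separates their values.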